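The source may hold more compounds than are shown below. What is called first, only, known or untested is meant among the compounds shown, and "the series" means these compounds.

Measured so far in (a functional assay on cells (Platelet, Homo sapiens) for inhibition; a higher number here means a weaker inhibitor, a lower number a stronger inhibitor)
- compound 1 (`CCOC(=O)c1ccc(-c2nn(Cc3cccc(Cl)c3)c3ccccc23)cc1`), a limit: (> 10000 nM)
- compound 2 (`CCOC(=O)c1ccc(-c2nn(CC)c3ccccc23)cc1`), a limit: (> 10000 nM)
- compound 3 (`O=C(O)c1ccc(-c2nn(Cc3ccccc3)c3ccccc23)cc1`), a limit: (> 10000 nM)

Compound 3 has no number, only a limit (> 10000 nM). Compound 4 (`NC(=O)c1ccc(-c2nn(Cc3ccccc3)c3ccccc23)cc1`) carries amino in place of hydroxy on a carbonyl carbon, which turns carboxy to carbamoyl (amino in place of hydroxy on a carbonyl carbon). Within the data shown here, the one measured step (a step that the two limits leave unreadable from compound 1 to compound 2) lies elsewhere in the molecule and has no readable size, so it gives no guide. All three measured compounds sit at the same limit (the limit of > 10000 nM in this assay, at which 3 of the 3 values shown sit). No step beyond the scatter, in either direction, is therefore expected in (this assay), and another limit is the likeliest report. The expected step is (a step that the limit leaves unreadable from compound 3 to compound 4). For compound 4 the estimated value is (12000 nM), with an expected range from (4000 nM) to (30000 nM).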

Compound 4, half-maximal inhibitory concentration: > 10000 nM
Compound 4 gave a limit, no number (the forecaster's own chance of this, stated with the estimate: 75%); the middle value is on the limit's open side.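

In this assay, among these compounds, compound 3 and compound 4 both give only a limit, so no step between them can be read. The compounds shown leave open whether any change to the shared core yields a measurable value, as all results sit at one limit: the limit of > 10000 nM in this assay, at which 4 of the 4 values shown sit.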